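Oxindole-pyrrole series: cyano in place of trifluoromethyl

This account rests on a few compounds, and the source may have more. Where it says the series, first, only, none or still open, it means among the compounds named here.

Measured compounds:
compound 1, `COc1ccc2c(c1)/C(=C/c1cc3c([nH]1)CCN(C(=O)N1CCN(C)CC1)C3)C(=O)N2`, 6 nM in an assay on isolated protein for inhibition of proto-oncogene tyrosine-protein kinase receptor Ret (Homo sapiens); a lower number here means a stronger inhibitor, a higher number a weaker inhibitor
compound 2, `CC(=O)N1CCc2[nH]c(/C=C3\C(=O)Nc4ccc(OC(C)C)cc43)cc2C1`, 150 nM in this assay
compound 3, `CC(=O)N1CCc2[nH]c(/C=C3\C(=O)Nc4ccc(C(F)(F)F)cc43)cc2C1`, 300 nM in this assay

Compound 3 sits at the high end of the numbers shown in this assay: compound 1 gives a far lower number, beyond the scatter, while the step of a 2.0-fold higher number from compound 2 to compound 3 (0.30 log units; within the scatter) stays within it. Compound 4, `CC(=O)N1CCc2[nH]c(/C=C3\C(=O)Nc4ccc(C#N)cc43)cc2C1`, differs from compound 3 by cyano in place of trifluoromethyl on an aromatic carbon. Among the measured compounds shown here, no measured step swaps these two groups, so the only bearing comes from a 2.0-fold higher number from compound 2 to compound 3 (0.30 log units; within the scatter), which shows that exchanging one group at this position left the number essentially unchanged. A step of similar size, not beyond the scatter, is therefore expected: a 1.2-fold lower number from compound 3 to compound 4 (0.08 log units; within the scatter). Compound 4 is estimated at 250 nM in this assay, with a range from 80 nM to 800 nM.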

Compound 4, half-maximal inhibitory concentration: 4 nM
For compound 4 the middle estimate is 63-fold (1.80 log units) above the measured one, and the stated range ends above it.
By their numbers in this assay, from the lowest: compounds 4 and 1 (each within the scatter of the next); then compounds 2 and 3 (each within the scatter of the next).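

In this assay this aromatic carbon is not indifferent to the group it carries: cyano in place of trifluoromethyl brings a 75-fold lower number from compound 3 to compound 4 (1.88 log units; beyond the scatter) and cyano in place of isopropoxy brings a 38-fold lower number from compound 2 to compound 4 (1.57 log units; beyond the scatter) in the same series. The exchange of isopropoxy for trifluoromethyl had stayed within the scatter (a 2.0-fold higher number from compound 2 to compound 3 (0.30 log units; within the scatter)), so only cyano separates from the other groups here. No supporting measurement accounts for this step.
As far as these compounds go, whether the large shift is particular to cyano remains open. An amine, a carboxylic acid or a carboxamide on this aromatic carbon would test that.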